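Compound 3 to compound 4: trifluoromethyl in place of bromo

The compounds below may be only part of what the source reports. "The series", "measured", "known", "first", "only" and "open" are said of these compounds alone.

In a functional assay on HepG2 cells (Homo sapiens) for cytotoxicity, with a stated time of 24 h (on this read-out lower numbers stand for stronger inhibition and higher numbers for weaker inhibition), compound 3 (`COc1cc(Cl)ccc1C(=O)Nc1cc(Br)ccc1O`) gives 5630 nM. Compound 1 (`COc1cc(Cl)ccc1C(=O)Nc1ccc(Cl)cc1O`) gives 7340 nM, within the scatter of that number, while compound 2 (`COc1cc(Cl)ccc1C(=O)Nc1cc(Cl)ccc1O`) gives 87000 nM, far higher than both.

Compound 4 (`COc1cc(Cl)ccc1C(=O)Nc1cc(C(F)(F)F)ccc1O`) is reached from compound 3 by one change: trifluoromethyl in place of bromo on an aromatic carbon. The group sits para to a hydroxy group.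

For the measured compounds named here, only one measured step bears on this carbon: a 15-fold lower number from compound 2 to compound 3 (1.19 log units; beyond the scatter), large and beyond the scatter, with bromo in place of chloro. Going by the values given here, the data hold no earlier trifluoromethyl compound, so that size does not carry over and the direction stays open.

The expected result is a 1.2-fold higher number from compound 3 to compound 4 (0.09 log units; within the scatter), with no clear shift beyond the scatter. For compound 4 the estimate in this assay is 7000 nM, with an expected range of 2000 nM to 30000 nM.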

Compound 4, half-maximal inhibitory concentration: 25400 nM
The estimate for compound 4 lay 3.6-fold (0.56 log units) below the measured number, within the range that was stated.
By their numbers in this assay, from the lowest: compounds 3 and 1 (each within the scatter of the next); then compound 4; then compound 2.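

On the carbon para to a hydroxy group, this assay now gives three groups to compare rather than two: the change shows a 4.5-fold higher number from compound 3 to compound 4 (0.65 log units; beyond the scatter) and a 3.4-fold lower number from compound 2 to compound 4 (0.53 log units; beyond the scatter). Trifluoromethyl therefore falls between bromo and chloro at this position, with both gaps beyond the scatter. Nothing in hand accounts for this order.

From the compounds shown here alone, whether the order extends to a nitrile, an amine or a carboxylic acid on the same carbon stays open. Also open, going by these compounds, is whether the same three groups would rank alike on another carbon of this ring.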